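Benzoyl to Methylpyrimidinyl: Expecting No Change

The source may hold more compounds than are shown below. What is called first, only, known or untested is meant among the compounds shown, and "the series" means these compounds.

In an ADME assay on PC-3 cells (Homo sapiens) for cytotoxicity, read by CCK-8 assay, with a stated time of 6 days (on this read-out higher numbers stand for weaker inhibition and lower numbers for stronger inhibition), compound 1 `CC(=O)c1cc(C(=O)N[C@@H](C)Cn2ccc(-c3cc(F)c(C#N)c(Cl)c3)n2)n[nH]1` gives > 30000 nM, which is a limit of the assay rather than a measured number. Compound 2 `C[C@@H](Cn1ccc(-c2ccc(C#N)c(Cl)c2)n1)NC(=O)c1ccccc1` in this assay gives > 30000 nM, again a limit and not a number. Both measured values therefore sit at the same place, namely (the limit of > 30000 nM in this assay, at which 2 of the 2 values shown sit). Compound 3 `Cc1ccnc(N[C@@H](C)Cn2ccc(-c3ccc(C#N)c(Cl)c3)n2)n1` differs from compound 2 by 4-methylpyrimidin-2-yl in place of benzoyl on an amine nitrogen. For the measured compounds named here, with no measured step between compounds to draw on, the step of a number no higher from compound 2 to compound 3 (the limit leaves the size open) is expected to stay within the usual scatter, in no particular direction. Compound 3 is accordingly estimated at 30000 nM, within 10000 nM to 100000 nM, and most likely reported once more only as a limit.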

Compound 3, half-maximal inhibitory concentration: > 30000 nM
Compound 3: no number, only a limit; the forecaster's own chance of this, stated with the estimate: 80%; the middle value lies on the limit itself.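

Compound 2 and compound 3 both give only a limit, so no step can be read between them: the limit of > 30000 nM in this assay, at which 3 of the 3 values shown sit.

The compounds shown leave open whether 4-methylpyrimidin-2-yl in place of benzoyl changes anything, and what the true value of any of them is.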